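A few compounds are considered here, and "the series" means these few. Any claim that something is new, unique, unknown or untested is made for them only; others in the source may bear on it.

For the measured compounds named here, in an ADME assay on BJ cells (Homo sapiens) for antiproliferative activity, with a stated time of 72 h (a lower number here means that less compound is needed, a higher number that more compound is needed for the effect), compound 1 `C=CCNC(=O)n1c(-c2ccc(OC)cc2)cc(=O)c2c(OC)cc(OC)cc21` gives 74000 nM, the only number so far. Compound 2 `COc1ccc(-c2[nH]c3cc(OC)cc(OC)c3c(=O)c2I)cc1` is reported only as a limit, > 86200 nM. The line the limit of > 86200 nM in this assay, at which 1 of the 2 values shown sits, offers no direction for further changes. Compound 3 `COc1ccc(-c2cc(=O)c3c(OC)cc(OC)cc3n2S(=O)(=O)c2ccc(F)cc2)cc1` differs from compound 1 by (4-fluorophenyl)sulfonyl in place of allylcarbamoyl on an aromatic nitrogen. Going by the values given here, no measured step on this kind of exchange is at hand in this assay, so the expected step of a 1.3-fold lower number from compound 1 to compound 3 (0.13 log units; within the scatter) is taken as small, within the scatter, in either direction. Compound 3 is estimated at 55000 nM, with a range of 15000 nM to 160000 nM.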

Compound 3, half-maximal effective concentration: > 65500 nM
Compound 3: no number, only a limit; the forecaster's own chance of this, stated with the estimate: 35%; middle value at least 1.1-fold (0.07 log units) away from the limit.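

For the compounds shown here, compound 3 is reported only as a limit, > 65500 nM, so no step from compound 1 to compound 3 can be read. The compounds shown leave open the size and direction of the change when (4-fluorophenyl)sulfonyl replaces allylcarbamoyl on the aromatic nitrogen.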